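Compound 3 and its hex-3-en-1-yl isomer, compound 4

The source may hold more compounds than are shown below. What is called first, only, known or untested is meant among the compounds shown, and "the series" means these compounds.

In a functional assay (plasma) for inhibition, with Homo sapiens as the target (a higher number here means a weaker inhibitor, a lower number a stronger inhibitor), compound 3 (`CCC/C=C/COCC1C2CCC(O2)C1C/C=C\CCCC(=O)O`) gives 300 nM, alongside two further entries that give no single number. Compound 1 (`CCCCCCOC[C@@H]1C2CCC(O2)[C@H]1C/C=C\CCCC(=O)O`) gives 25000 nM; 18000 nM; 500 nM (3 entries), and compound 2 (`CCCCCCOC[C@@H]1C2CCC(O2)[C@@H]1C/C=C\CCCC(=O)O`) gives 38500 nM; 10000 nM (2 entries). The number for compound 3 lies clearly under both entries of compound 2, but near only the lowest entry of compound 1.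

Compound 4 (`CC/C=C/CCOCC1C2CCC(O2)C1C/C=C\CCCC(=O)O`) has the same atoms joined differently, with pent-2-en-1-yl in place of pent-1-en-1-yl on a saturated chain carbon bound to an oxygen on a saturated carbon. Going by the values given here, no measured pair covers this change, so the expected step in this assay is a 1.3-fold higher number from compound 3 to compound 4 (0.12 log units; within the scatter), none beyond the scatter. For compound 4 the estimated value is 400 nM, within an expected range of 120 nM to 1500 nM.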

Compound 4, half-maximal inhibitory concentration: 500 nM
Compound 4: the middle estimate sits 1.3-fold (0.10 log units) below what was measured; low and high end bracket the measured number.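

In this assay, shifting the double bond along the chain, from hex-2-en-1-yl to hex-3-en-1-yl, gives a 1.7-fold higher number from compound 3 to compound 4 (0.22 log units; within the scatter). Going by these compounds alone, this is the first comparison of compounds that differ in one place, and it shows that this shift on a saturated chain carbon bound to an oxygen leaves the number within the scatter. Repeated entries for a single compound can spread far wider than this step: the several entries of compound 1 in this assay, 25000 nM; 18000 nM; 500 nM (3 entries). As far as these compounds go, whether a terminal hydroxyl or an amine on this chain would move the number beyond the scatter remains open.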